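Trimming the Ether Chain: From Allyloxy to Ethoxy

The compounds below may be only part of what the source reports. "The series", "measured", "known", "first", "only" and "open" are said of these compounds alone.

Compound 1 `CN(C)CCNc1ccnc2cc(OCc3ccc(F)cc3)ccc12`: in a functional assay on BGC-823 cells (Homo sapiens) for cytotoxicity, read by MTT assay, with a stated time of 48 h (a higher number here means a weaker inhibitor, a lower number a stronger inhibitor), compound 1 gives 890 nM
Compound 2 `CCCCCCOc1ccc2c(Cl)ccnc2c1`: in this assay compound 2 gives 2380 nM
Compound 3 `C=CCOc1ccc2c(NCCN(C)C)ccnc2c1`: in this assay compound 3 gives 1360 nM

Three compounds share a core and differ in the group attached to the oxygen on the aromatic ring. In this assay compound 3 gives a number that sits close to both neighbours: compound 1 is within the scatter of it, and so is compound 2, so none of the three can be told apart with confidence on these numbers alone.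

Compound 4 `CCOc1ccc2c(NCCN(C)C)ccnc2c1` is the next step: methyl in place of vinyl on a saturated chain carbon bound to an oxygen on an aromatic ring. Going by the values given here, the one measured step that bears on this place is a 1.5-fold higher number from compound 1 to compound 3 (0.18 log units; within the scatter), a change at the same carbon that left the number essentially where it was. Shortening the chain by one carbon is a smaller change still, so the expectation is a step of a 1.1-fold higher number from compound 3 to compound 4 (0.04 log units; within the scatter), with no movement beyond the scatter in either direction.

Compound 4 is therefore expected to give about 1500 nM in this assay, with a likely range from 600 nM to 4000 nM.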

Compound 4, half-maximal inhibitory concentration: 2520 nM
Compound 4: the middle estimate sits 1.7-fold (0.23 log units) below what was measured; the measured number falls inside the stated range.
By their numbers in this assay, from the lowest: compounds 1, 3, 2 and 4 (each within the scatter of the next, the first and the last beyond it).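

In this assay, trimming allyloxy to ethoxy gives a 1.9-fold higher number from compound 3 to compound 4 (0.27 log units; within the scatter) and so does not separate vinyl from methyl at this place. Going by these compounds alone, the new information comes from the wider swap at the same saturated chain carbon, where methyl in place of 4-fluorophenyl gives a 2.8-fold higher number from compound 1 to compound 4 (0.45 log units; beyond the scatter) and is the first step at this position to clear the scatter, though only modestly. Nothing measured here offers an explanation for that step.

The compounds shown leave open whether the fluorine matters, since a plain phenyl at this carbon would be needed to separate its contribution from that of the ring. They also leave open how a terminal amine or a carboxylic acid on the ether chain would read, with the dimethylaminoethylamino side of the core kept unchanged.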